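A Phenyl to Cyclopropyl Swap on a Weak Phosphatase Inhibitor

A few compounds are considered here, and "the series" means these few. Any claim that something is new, unique, unknown or untested is made for them only; others in the source may bear on it.

Compound 1 `O=C(COc1ccc2cc(C(O)(C(F)(F)F)C(F)(F)F)c(O)cc2c1)Nc1ccccc1` is weak in an assay on isolated protein for inhibition of receptor-type tyrosine-protein phosphatase C (Homo sapiens), read by spectrophotometry; a lower number here means a stronger inhibitor, a higher number a weaker inhibitor. In this assay compound 1 gives only a limit, > 20000 nM, so it sits at the limit of > 20000 nM in this assay, at which 1 of the 2 values shown sits, and cannot be ranked. Compound 2 `O=C(COc1ccc2cc(C(O)(C(F)(F)F)C(F)(F)F)c(O)cc2c1)Nc1cccc2ccccc12` in this assay gives 29100 nM. The step that the limit leaves unreadable from compound 1 to compound 2 therefore cannot be read. Compound 3 `O=C(COc1ccc2cc(C(O)(C(F)(F)F)C(F)(F)F)c(O)cc2c1)NC1CC1` differs from compound 1 by cyclopropyl in place of phenyl on an amide-type nitrogen. Within the data shown here, no measured step bears directly on this change, and the one neighbouring step is unreadable, so no direction can be drawn from it. Compound 3 is expected to remain weak, with an estimated step that the limit leaves unreadable from compound 1 to compound 3. Compound 3 is estimated at 30000 nM, within a range from 12000 nM to 90000 nM.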

Compound 3, half-maximal inhibitory concentration: > 20000 nM
Compound 3 was reported as a limit (the forecaster's own chance of this, stated with the estimate: 70%); the middle value does not contradict the limit.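

No step from compound 1 or compound 2 to compound 3 can be read, since compound 3 gives only a limit: the limit of > 20000 nM in this assay, at which 2 of the 3 values shown sit.

On these data alone, whether compound 1 and compound 3 differ at all in this assay remains open.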